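The source may report more compounds than this note shows. Statements on the series, on what has been measured and on what is new or still open speak of the compounds shown alone.

Compound 1 `CN1CCN(Cc2c([O-])on[n+]2-c2ccc(Cc3ccc(-[n+]4noc([O-])c4CN4CCN(C)C(c5ccccc5)C4)cc3)cc2)CC1c1ccccc1` gives 14 ug/mL
Compound 2 `Cc1ccc(-[n+]2noc([O-])c2CN2CCN(c3cccc(Cl)c3Cl)CC2)cc1` gives 31.7 ug/mL
Compound 3 `Cc1ccc(-[n+]2noc([O-])c2CN2CCN(C)C(c3ccccc3)C2)cc1` gives 14.4 ug/mL

These values come from an ADME assay on MT4 cells (Homo sapiens) for cytotoxicity, read by MTT assay; on this read-out lower numbers stand for higher toxicity in this test and higher numbers for lower toxicity in this test. Compound 2 stands highest of the three (31.7 ug/mL), and compounds 1 and 3 both lie below it by more than the scatter. Compound 4 `Cc1ccc(-[n+]2noc([O-])c2CN2CCN(c3ccccc3)CC2)cc1` has phenyl in place of 2,3-dichlorophenyl on an amine nitrogen in a ring. Going by the values given here, no pair of measured compounds shows a single change, so the three values give no direct guide to this one. Only a small change is expected, with no direction beyond the scatter, and the estimated step is (a 1.1-fold lower number from compound 2 to compound 4 (0.02 log units; within the scatter)). The estimate for compound 4 is 30 ug/mL, with an expected range from 12 ug/mL to 75 ug/mL.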

Compound 4, half-maximal cytotoxic concentration: 13.2 ug/mL
Compound 4: the middle estimate sits 2.3-fold (0.36 log units) above what was measured, and the stated range covers the measured number.
By their numbers in this assay, from the lowest: compounds 4, 1 and 3 (each within the scatter of the next); then compound 2.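

In this assay phenyl in place of 2,3-dichlorophenyl on an amine nitrogen in a ring gives a 2.4-fold lower number from compound 2 to compound 4 (0.38 log units; beyond the scatter) as a modest step. This is the first single change shown, and it indicates that this position affects the read-out: the two chlorine atoms go with the higher number, meaning lower toxicity in this test. No measurement here accounts for the step.

Going by these compounds, whether either chlorine alone would carry the step stays open. So does the result for a fluorine or a methoxy group on that phenyl.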